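Removing a Methyl from the Most Active of Three

A few compounds are considered here, and "the series" means these few. Any claim that something is new, unique, unknown or untested is made for them only; others in the source may bear on it.

Of the compounds shown here, three have been measured in a functional assay on NCI-H460 cells (Homo sapiens) for antiproliferative activity, read by CCK-8 assay, with a stated time of 72 h, tested at 2 uM; on this read-out higher numbers stand for a stronger effect at the one concentration tested and lower numbers for a weaker effect. Compound 1 `CCCCn1cnc2c(Nc3cccc(Cl)c3)nc(NCOCc3ccc(/C=C/C(=O)Nc4ccccc4N)cc3)nc21` gives 25.7% and compound 2 `CC(C)n1cnc2c(Nc3ccccc3)nc(NCOCc3ccc(/C=C/C(=O)Nc4ccccc4N)cc3)nc21` gives 41% in this assay. Compound 3 `Cc1ccc(Nc2nc(Cl)nc3c2ncn3Cc2ccc(C(=O)Nc3ccccc3N)cc2)cc1` gives 67.3%, the highest of the three numbers; compound 2 is its nearest neighbour, lower by a margin beyond the scatter, and compound 1 is the furthest, also beyond the scatter.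

Compound 4 `Nc1ccccc1NC(=O)c1ccc(Cn2cnc3c(Nc4ccccc4)nc(Cl)nc32)cc1` has not yet been measured in this assay. It differs from compound 3 in one place: hydrogen in place of methyl on an aromatic carbon. Read one bond further out, a 4-methylphenyl becomes a phenyl, and a (4-methylphenyl)amino group becomes an anilino group; the place is an aromatic carbon of a six-membered aromatic ring of carbon only, para to a large group.

Within the data shown here, no two measured compounds differ only in this way, so the size of this step in this assay has no direct precedent. Compound 1 and compound 2 each carry several other changes alongside the ring substituent, so their values cannot be read as a guide to this single change. The step from compound 3 to compound 4 is expected to be small, a number 7.3 percentage points lower from compound 3 to compound 4 (within the scatter), and probably within the scatter, if anything slightly downward. Compound 4 is therefore expected to give about 60% in this assay, within a range of 40% to 76%.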

Compound 4, a percentage reported as inhibition, at one concentration (the size of the read-out at that concentration, not a potency): 42.7%
For compound 4 the middle estimate is 17.3 percentage points above the measured one, within the range that was stated.
By their numbers in this assay, from the lowest: compound 1; then compounds 2 and 4 (each within the scatter of the next); then compound 3.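

In this assay, among these compounds, replacing the 4-methylphenyl with a phenyl gives a number 24.6 percentage points lower from compound 3 to compound 4 (beyond the scatter), the first direct reading of a change at this aromatic carbon, para to a large group. Compound 1 and compound 2 could not show this, since neither forms a one-place pair with another compound, whereas this pair shows that the read-out at the one concentration tested responds to the loss of a single carbon here, on this shared core. Why the number falls cannot be said, since no measurement at hand bears on the reason.

On these data alone, it remains open whether the methyl itself matters or whether other groups on this aromatic carbon, such as an ethyl, a methoxy or an amine, would hold the number of compound 3, lower it as hydrogen does, or raise it. Also open, as far as these compounds go, is whether the same change would give a step of similar size on the cores of compound 1 and compound 2, which carry a longer side chain with a cinnamide-type amide in place of the benzamide and the chlorine of compound 3 and compound 4.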